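The compounds below may be only part of what the source reports. "The series", "measured", "known", "first", "only" and "open" are said of these compounds alone.

The three measured compounds:
Compound 1, `CN(C)C(=O)c1cc2cnc(Nc3ccc(NC(=O)C4(C(=O)Nc5cccc(Cl)c5)CC4)cc3)nc2n1C1CCCC1`, gives 8.3% in a functional assay on A549 cells (Homo sapiens) for inhibition, read by CCK-8 assay, with a stated time of 72 h, tested at 1 uM; on this read-out lower numbers stand for less inhibition of growth and higher numbers for more inhibition of growth at the one concentration tested.
Compound 2, `CN(C)C(=O)c1cc2cnc(Nc3ccc(NC(=O)C4(C(=O)Nc5cccc(Br)c5)CC4)cc3)nc2n1C1CCCC1`, gives 20.2% in this assay.
Compound 3, `Cc1ccc(NC(=O)C2(C(=O)Nc3ccc(Nc4ncc5cc(C(=O)N(C)C)n(C6CCCC6)c5n4)cc3)CC2)cc1`, gives 40.2% in this assay.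

Compound 3 stands highest of the three, separated from both others beyond the scatter, as the steps of a number 31.9 percentage points higher from compound 1 to compound 3 (beyond the scatter) and a number 20 percentage points higher from compound 2 to compound 3 (beyond the scatter) show. Compound 4, `CN(C)C(=O)c1cc2cnc(Nc3ccc(NC(=O)C4(C(=O)Nc5cccc(F)c5)CC4)cc3)nc2n1C1CCCC1`, is not yet measured; it differs from compound 3 by 3-fluorophenyl in place of 4-methylphenyl on an amide-type nitrogen. The two steps that bear on this change run in the opposite direction: replacing 3-chlorophenyl or 3-bromophenyl by 4-methylphenyl raised inhibition each time, and the step of a number 11.9 percentage points higher from compound 1 to compound 2 (beyond the scatter) shows that which halogen sits there also shifts the number modestly. The expected step is therefore a number 28.2 percentage points lower from compound 3 to compound 4 (beyond the scatter), a drop beyond the scatter. For compound 4 the estimate is 12%, with a range from 0% to 30%.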

Compound 4, percent growth inhibition at one concentration: 33.2%
Beside the measured number, compound 4's estimate is 21.2 percentage points below it, and the stated range ends below it.
By their numbers in this assay, from the lowest: compound 1; then compound 2; then compounds 4 and 3 (each within the scatter of the next).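

On this amide-type nitrogen, the choice of halogen matters: fluoro in place of bromo gives a number 13 percentage points higher from compound 2 to compound 4 (beyond the scatter), and fluoro in place of chloro gives a number 24.9 percentage points higher from compound 1 to compound 4 (beyond the scatter). A halogen-bearing ring can also read level with 4-methylphenyl, as a number 7 percentage points lower from compound 3 to compound 4 (within the scatter) shows, so the earlier rises did not set 4-methylphenyl apart from every halogenated ring. Nothing available explains why fluoro differs from chloro and bromo.

On these data alone, how 4-fluorophenyl or 3-methylphenyl would read remains open. Until then, the effect of the group's identity cannot be separated from that of its place on the ring.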